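Inverting the aminoethyl stereocentre in a piperazine amide series

The source may report more compounds than this note shows. Statements on the series, on what has been measured and on what is new or still open speak of the compounds shown alone.

Compound 1 `Cc1ccc(N2CCN(C(=O)[C@@H]3CN(C4CCOCC4)C[C@H]3c3ccc(Cl)cc3)CC2)c([C@@H](NC(=O)CN)C(C)C)c1`: 2 nM
Compound 2 `CNCC(=O)N[C@H](c1cc(C)ccc1N1CCN(C(=O)[C@@H]2CN(C3CCOCC3)C[C@H]2c2ccc(Cl)cc2)CC1)C(C)C`: 2.1 nM
Compound 3 `Cc1ccc(N2CCN(C(=O)[C@@H]3CN(C4CCOCC4)C[C@H]3c3ccc(Cl)cc3)CC2)c([C@@H](NC(=O)[C@H](C)N)C(C)C)c1`: 1 nM

In an assay on HEK293 cells for displacement of a labelled ligand from Melanocortin receptor 4 (Homo sapiens) (a lower number here means a stronger inhibitor, a higher number a weaker inhibitor), compound 3 gives 1 nM, the lowest of the three numbers, though its gap to compound 1 lies within the scatter. Compound 4 `Cc1ccc(N2CCN(C(=O)[C@@H]3CN(C4CCOCC4)C[C@H]3c3ccc(Cl)cc3)CC2)c([C@@H](NC(=O)[C@@H](C)N)C(C)C)c1` differs from it only in configuration: the two compounds have the same atoms and bonds and differ only in configuration as drawn: 1 of 4 stereo elements differ; a stereocentre at a saturated chain carbon is drawn S in compound 3 and R in compound 4. Among the measured compounds shown here, no measured pair tests such an inversion; the nearest comparison is a 2.0-fold lower number from compound 1 to compound 3 (0.30 log units; within the scatter), which shows that adding the methyl at this chain carbon changed little. Whether the mirror-image arrangement behaves the same cannot be read from these compounds, so a modest drift in either direction is as plausible as none. Compound 4 is therefore expected near 2.5 nM, within 0.7 nM to 9 nM, corresponding to an estimated 2.5-fold higher number from compound 3 to compound 4 (0.40 log units; beyond the scatter).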

Compound 4, inhibition constant: 7.3 nM
Estimate against measurement, compound 4: 2.9-fold (0.47 log units) below, within the range that was stated.
By their numbers in this assay, from the lowest: compounds 3, 1 and 2 (each within the scatter of the next, the first and the last beyond it); then compound 4.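

In this assay, this saturated chain carbon proves sensitive to configuration, with a 7.3-fold higher number from compound 3 to compound 4 (0.86 log units; beyond the scatter), and that shift belongs to the one stereocentre: the fact that compounds 3 and 4 differ only in the configuration as drawn. The methyl drawn R gives a 3.7-fold higher number from compound 1 to compound 4 (0.56 log units; beyond the scatter), whereas the methyl drawn S gave only a 2.0-fold lower number from compound 1 to compound 3 (0.30 log units; within the scatter), so the earlier near-silence of this methyl holds for one configuration only. The R-configured 1-aminoethyl group also stands apart from the (methylamino)methyl group, with a 3.5-fold higher number from compound 2 to compound 4 (0.54 log units; beyond the scatter).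

As far as these compounds go, whether the same preference holds for an ethyl or isopropyl group at this carbon remains open. So does the effect of inverting this centre with an N-methylated amine in place of the primary amine.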